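The compounds below may be only part of what the source reports. "The series", "measured", "known", "first", "only" and "open" are said of these compounds alone.

Working notes on the series. Compound 1 `COc1cc(/C=C2\CN(C)C/C(=C\c3ccc(Cl)cc3)C2=O)cc(OC)c1` and compound 2 `COc1cc(/C=C2\CN(C)C/C(=C\c3ccc(Br)cc3)C2=O)cc(OC)c1` share one core; compound 3 `CN1C/C(=C\c2ccc(Cl)cc2)C(=O)/C(=C/c2ccc(C#N)cc2)C1` and compound 4 `CN1C/C(=C\c2ccc(Br)cc2)C(=O)/C(=C/c2ccc(C#N)cc2)C1` share a second. The difference between the two cores is not broken down here. In a functional assay on K562 cells (Homo sapiens) for cytotoxicity, read by MTT assay, with a stated time of 24 h (a higher number here means a weaker inhibitor, a lower number a stronger inhibitor), compound 1 gives 13300 nM, compound 2 gives 7420 nM, and compound 3 gives 13300 nM.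

For the measured compounds named here, the one counted change on the first core is bromo in place of chloro on an aromatic carbon, which made a step of a 1.8-fold lower number from compound 1 to compound 2 (0.25 log units; within the scatter). Compound 3 and compound 1 stand level at the digits printed in this assay; no order between them is claimed.

Compound 4 carries the same kind of change on the second core: bromo in place of chloro on an aromatic carbon. Both changes sit on the same kind of place, para to a large group on a six-membered aromatic ring of carbon only. A step of about the same size is expected from compound 3 to compound 4, namely a 1.7-fold lower number from compound 3 to compound 4 (0.22 log units; within the scatter), because compound 1 to compound 2 gave a 1.8-fold lower number from compound 1 to compound 2 (0.25 log units; within the scatter). Compound 4 is therefore estimated at 8000 nM in this assay, with a range of 4000 nM to 16000 nM.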

Compound 4, half-maximal inhibitory concentration: 7420 nM
Estimate against measurement, compound 4: 1.1-fold (0.03 log units) above; low and high end bracket the measured number.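

In this assay, bromo in place of chloro on an aromatic carbon gives a 1.8-fold lower number from compound 3 to compound 4 (0.25 log units; within the scatter), and the step on the second core matches the step on the first: the same change on two cores in this assay, a 1.8-fold lower number (0.25 log units; within the scatter) from compound 1 to compound 2 and a 1.8-fold lower number (0.25 log units; within the scatter) from compound 3 to compound 4, 1.0-fold (0.00 log units) apart, within the scatter of two such steps Within these two cores, the change therefore carries over with its size intact, and the two pairs read alike. This does not show that bromo and chloro differ in this assay, since each step lies within the scatter, and two cores in a single cell assay cannot establish that the match holds on any other core or in any other read-out.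

Open, from the compounds shown here alone, is how the series responds to a larger departure at the same place, such as fluoro, an amine or a carboxylic acid in place of the halogen of the 4-chlorophenyl group. Also open, going by these compounds, is the part played by the other aromatic group, since the two cores differ there and that difference is not broken down in these compounds.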